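The compounds below may be only part of what the source reports. "The series", "measured", "known", "first", "only" and "open" are said of these compounds alone.

Working notes on the series. Two compounds have been run in a functional assay on the whole organism with Rattus norvegicus as the target (a lower number here means that less compound is needed, a higher number that more compound is needed for the effect), so far. Compound 1 `CCC(C)(C)Nc1c(NCc2c(C)cc(Cl)cc2Cl)c(=O)c1=O` gives 0.6 mg/kg in this assay. Compound 2 `CC1(C)Oc2ccc(OC(F)(F)F)cc2[C@@H](N2Cc3ccccc3C2=O)[C@@H]1O` gives 0.3 mg/kg in this assay, a gap to compound 1 that lies within the scatter, so the two cannot be separated on these numbers. Compound 3 `CCCC(=O)N(Cc1c(C)cc(Cl)cc1Cl)c1c(NC(C)(C)CC)c(=O)c1=O` is the next entry, differing from compound 1 by propylcarbonyl in place of hydrogen on a nitrogen on an aromatic ring. For the measured compounds named here, no comparable step has been measured, so the direction is open. The expectation is a step from compound 1 to compound 3 of a 1.3-fold higher number from compound 1 to compound 3 (0.12 log units; within the scatter), within the scatter. Compound 3 is estimated at 0.8 mg/kg, in the range 0.3 mg/kg to 2.5 mg/kg.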

Compound 3, dose for half-maximal effect: 3.9 mg/kg
The estimate for compound 3 lay 4.9-fold (0.69 log units) below the measured number, outside the stated range (above it).
By their numbers in this assay, from the lowest: compounds 2 and 1 (each within the scatter of the next); then compound 3.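

In this assay, the first step readable in the series is a 6.5-fold higher number from compound 1 to compound 3 (0.81 log units; beyond the scatter): with propylcarbonyl in place of hydrogen on this nitrogen, more compound is needed for the effect. The hydrogen at this position therefore cannot be exchanged for propylcarbonyl without a loss beyond the scatter, although this single change does not describe the position as a whole.

From the compounds shown here alone, whether a smaller acetyl group, a simple methyl group or a basic aminoalkyl chain on this nitrogen would move the number in the same direction remains open. Nothing on hand bears on the reason for this step.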